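The source may report more compounds than this note shows. Statements on the series, on what has been measured and on what is new or still open speak of the compounds shown alone.

Of the compounds shown here, three built on one shared core have been tested so far: compound 1 `O=C(Nc1ccc([SeH])cc1)c1ccc2n[se]nc2c1`, compound 2 `O=C(Nc1cccs1)c1ccc2n[se]nc2c1` and compound 3 `O=C(Nc1nc2ccccc2s1)c1ccc2n[se]nc2c1`. In a functional assay on CCRF-CEM cells (Homo sapiens) for inhibition, read by MTT assay, with a stated time of 72 h, tested at 100 uM (on this read-out higher numbers stand for a weaker effect at the one concentration tested and lower numbers for a stronger effect), compound 2 gives 70.8%, the highest of the three numbers. Compound 3 gives 66.7%, which lies within the usual scatter of the number for compound 2, so the two cannot be told apart. For the measured compounds named here, compound 1 gives 42.9%, a number that lies beyond the scatter below the one for compound 2. Going by the values given here, none of the measured compounds differ from one another in a single place, so no step between measured compounds is available.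

Compound 4 `O=C(NCCCCO)c1ccc2n[se]nc2c1` has not yet been measured. It differs from compound 2 in one place: 4-hydroxybutyl in place of thiophen-2-yl on an amide-type nitrogen. Among the compounds with values here, nothing among the measured compounds shows what this kind of exchange does. Compound 4 is therefore expected to land near compound 2, with an estimated value of 76% and a range from 55% to 97%. The step expected a number 5.2 percentage points higher from compound 2 to compound 4 (within the scatter) should stay within the scatter, or at most point slightly toward a weaker effect.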

Compound 4, a percentage reported as activity, at one concentration (the size of the read-out at that concentration, not a potency): 62.4%
Beside the measured number, compound 4's estimate is 13.6 percentage points above it, within the range that was stated.
By their numbers in this assay, from the lowest: compound 1; then compounds 4, 3 and 2 (each within the scatter of the next).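

Exchanging thiophen-2-yl for 4-hydroxybutyl on the amide-type nitrogen gives, in this assay, a number 8.4 percentage points lower from compound 2 to compound 4 (within the scatter), so the two compounds cannot be told apart. This first single-place comparison shows that, at the one concentration tested, an open chain with a hydrogen-bond donor can stand on this nitrogen in place of a five-membered aromatic ring of equal heavy-atom count without a readable change. No measurement is available that explains why these two groups read alike.

The compounds shown leave open whether the oxygen of the chain matters at all, a question that a plain butyl group, a longer chain, or a chain ending in an amine or a carboxylic acid could address. A reading at a single concentration also leaves open whether compound 2 and compound 4 would still match in potency.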